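Swapping the benzyl arene for a neopentyl chain

The source may hold more compounds than are shown below. What is called first, only, known or untested is meant among the compounds shown, and "the series" means these compounds.

Compound 1 `O=C(O)c1ccccc1-c1ccc(CCc2ncc(Cc3ccccc3F)[nH]2)cc1`: 9.5 nM
Compound 2 `Cc1cccc(Cc2cnc(CCc3ccc(-c4ccccc4C(=O)O)cc3)[nH]2)c1`: 75 nM
Compound 3 `N#Cc1ccccc1Cc1cnc(CCc2ccc(-c3ccccc3C(=O)O)cc2)[nH]1`: 642 nM

In an in vitro functional assay on cells for agonist activity at Bombesin receptor subtype-3 (Mus musculus), read by luminescence and calcium flux (a higher number here means that more compound is needed for the effect, a lower number that less compound is needed), compound 1 gives 9.5 nM, the lowest number of the three. The two changes already measured both touch the same saturated chain carbon bound to an aromatic carbon: a 7.9-fold higher number from compound 1 to compound 2 (0.90 log units; beyond the scatter) and a 68-fold higher number from compound 1 to compound 3 (1.83 log units; beyond the scatter), while compound 2 and compound 3 sit apart by an 8.6-fold higher number from compound 2 to compound 3 (0.93 log units; beyond the scatter). Compound 4 `CC(C)(C)Cc1cnc(CCc2ccc(-c3ccccc3C(=O)O)cc2)[nH]1` goes further, replacing the whole ring: tert-butyl in place of 2-fluorophenyl on a saturated chain carbon bound to an aromatic carbon. Within the data shown here, no measured compound carries a non-aromatic group at this position, so the comparison rests on the two steps from compound 1, both of which raised the number beyond the scatter. Compound 4 is therefore expected to need more compound than compound 1 in this assay, by roughly a 16-fold higher number from compound 1 to compound 4 (1.20 log units; beyond the scatter), with wide uncertainty. The estimate for compound 4 is 150 nM, likely between 30 nM and 800 nM.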

Compound 4, half-maximal effective concentration: 6.3 nM
Beside the measured number, compound 4's estimate is 24-fold (1.38 log units) above it, and the stated range ends above it.
By their numbers in this assay, from the lowest: compounds 4 and 1 (each within the scatter of the next); then compound 2; then compound 3.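

In this assay, the aromatic ring at this position turns out not to be needed: tert-butyl in place of 2-fluorophenyl gives a 1.5-fold lower number from compound 1 to compound 4 (0.18 log units; within the scatter), even though the ring and its fluorine are gone. The same tert-butyl stands well apart from the other two aryl groups, with a 12-fold lower number from compound 2 to compound 4 (1.08 log units; beyond the scatter) and a 100-fold lower number from compound 3 to compound 4 (2.01 log units; beyond the scatter), so the rises seen with 3-methylphenyl and 2-cyanophenyl do not extend to every replacement of 2-fluorophenyl. No measurement given here explains why a group without a ring matches 2-fluorophenyl.

The compounds shown leave open whether a shorter or longer chain, such as isobutyl or n-hexyl, or a saturated ring such as cyclohexyl, would match neopentyl on this saturated chain carbon. They also leave open what an amine or an ether oxygen within that chain would do.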